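The source may report more compounds than this note shows. Statements on the series, on what has been measured and on what is new or still open speak of the compounds shown alone.

Measured so far:

Compound 1 `CCOC(=O)c1c(CN(CC)Cc2ccccc2)nc2ccccc2c1-c1ccccc1` gives 700 nM in an assay on brain with Translocator protein (Rattus norvegicus) as the target; a lower number here means a stronger inhibitor, a higher number a weaker inhibitor.
Compound 2 `CCN(Cc1ccccc1)Cc1nc2ccccc2c(-c2ccccc2)c1C(=O)N(C)C` gives 229 nM in this assay.

For the measured compounds named here, compound 2 stands at the lower of the two numbers, and the only measured step, a 3.1-fold lower number from compound 1 to compound 2 (0.49 log units; beyond the scatter), separates it from compound 1. Compound 3 `CCN(Cc1ccccc1)Cc1nc2ccccc2c(-c2ccccc2)c1C(=O)NCc1ccccc1` differs from compound 2 by benzylamino in place of dimethylamino on a carbonyl carbon. The measured step sits on the same carbonyl carbon, but it swapped an ester for an amide, whereas here one amide is exchanged for another; it therefore bears on the new change only loosely, and it shows that changes at this carbonyl carbon can move this assay by a modest amount. With nothing closer to go on, the expected step is small, a 1.7-fold higher number from compound 2 to compound 3 (0.24 log units; within the scatter), and could fall either way. Compound 3 is estimated at 400 nM, with a range from 100 nM to 2000 nM.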

Compound 3, half-maximal inhibitory concentration: 2900 nM
Estimate against measurement, compound 3: 7.3-fold (0.86 log units) below; measured number above the stated range.
By their numbers in this assay, from the lowest: compound 2; then compound 1; then compound 3.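

For the compounds shown here, the group on this carbonyl carbon matters much more in this assay than the ester-to-amide swap suggested: exchanging one amide for another gives a 13-fold higher number from compound 2 to compound 3 (1.10 log units; beyond the scatter) and is the largest step so far. Being an amide therefore does not by itself bring the number down, as benzylamino also compares poorly with the ethoxy of the ester, with a 4.1-fold higher number from compound 1 to compound 3 (0.62 log units; beyond the scatter) on that step. Nothing measured here accounts for either step.

Benzylamino brings in both a six-membered aromatic ring and an amide hydrogen, and the compounds shown leave open which of the two goes with the higher number. A methylamino group on the same carbonyl carbon would keep the hydrogen without the ring, while a benzyl(methyl)amino group would keep the ring without the hydrogen.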